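This account rests on a few compounds, and the source may have more. Where it says the series, first, only, none or still open, it means among the compounds named here.

In a functional assay on A549 cells (Homo sapiens) for inhibition, read by MTT assay, with a stated time of 24 h (on this read-out higher numbers stand for weaker inhibition and lower numbers for stronger inhibition), compound 1 `CCOC(=O)C1=Cc2ccccc2OC1(OCc1cn(-c2ccc(F)cc2)nn1)C(F)(F)F` gives 7300 nM. Among the measured compounds shown here, that is the only genuine number among the three measured compounds. Compound 2 `CCOC(=O)C1=Cc2ccccc2OC1(OCc1cc(-c2ccc(OC)cc2)no1)C(F)(F)F` gives > 150000 nM in this assay, which is a limit and not a number. Compound 3 `CCOC(=O)C1=Cc2ccccc2OC1(OCc1cc(-c2ccc3ccccc3c2)no1)C(F)(F)F` likewise gives > 150000 nM in this assay, again a limit rather than a number. Both ends of the step that the two limits leave unreadable from compound 2 to compound 3 are limits, and so its size cannot be read. The picture is summed up by the limit of > 150000 nM in this assay, at which 2 of the 3 values shown sit, which leaves compound 1 as the one point of reference.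

Compound 4 `CCOC(=O)C1=Cc2ccccc2OC1(OCc1cn(-c2ccc([N+](=O)[O-])cc2)nn1)C(F)(F)F` differs from compound 1 as follows: nitro in place of fluoro on an aromatic carbon. For the measured compounds named here, no measured step touches this change: the one step available, between compound 2 and compound 3, is unreadable, and neither of those compounds carries a fluoro or a nitro group at the same place as compound 1. There is therefore no measured evidence on which to base a shift in either direction, and the expectation is a step no larger than the usual scatter around the value of compound 1.

Compound 4 is thus estimated to give 7300 nM in this assay, with an expected range from 2500 nM to 25000 nM. This estimate means an expected step of no change at the digits printed from compound 1 to compound 4 (within the scatter).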

Compound 4, half-maximal inhibitory concentration: > 150000 nM
Compound 4 was reported as a limit; the forecaster's own chance of this, stated with the estimate: 10%; middle value at least 20-fold (1.31 log units) from the limit.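

Among the compounds shown here, changing 4-fluorophenyl to 4-nitrophenyl gives the first readable step, an at least 20-fold higher number from compound 1 to compound 4 (1.31 log units; beyond the scatter) in this assay, and on this read-out a higher number means weaker inhibition. This shows that the group at this place on the aromatic ring, para to a large group, can decide whether the core of compound 1 gives a measurable value at all. For the compounds shown here, the value of compound 4, > 150000 nM, is a limit and not a number, and with it compound 1 is left as the only compound of the four with a genuine value: the limit of > 150000 nM in this assay, at which 3 of the 4 values shown sit.

From the compounds shown here alone, what remains open is whether fluoro is specifically needed or whether another small group, such as chloro, an amine or a plain hydrogen, would also give a number at this place. Going by these compounds alone, only two groups have been compared here, and the step cannot be extended into a trend. The step between compound 2 and compound 3 cannot be read, and it adds nothing on how other groups behave.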